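Trifluoropropyl for Isopropyl on the Chain of Compound 2

The source may hold more compounds than are shown below. What is called first, only, known or untested is meant among the compounds shown, and "the series" means these compounds.

Two compounds in this set have a measured value. In a functional assay on CHO cells for positive allosteric modulation of metabotropic glutamate receptor 2 (Homo sapiens), with a stated time of 30 min (on this read-out lower numbers stand for an effect already at smaller amounts and higher numbers for an effect only at larger amounts of compound), compound 1 `CC(C)CCn1ccc(N2CCN(c3ccccc3)CC2)c(C#N)c1=O` gives 661 nM, and in this assay compound 2 `CC(C)Cn1ccc(N2CCC(c3ccccc3)CC2)c(C#N)c1=O` gives 282 nM. Compound 2 thus stands at the lowest of the two numbers, and its distance to compound 1 is beyond the usual scatter of repeated measurements.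

Compound 3 `N#Cc1c(N2CCC(c3ccccc3)CC2)ccn(CCCC(F)(F)F)c1=O` has not yet been measured in this assay. It differs from compound 2 in one place: 3,3,3-trifluoropropyl in place of isopropyl on a saturated chain carbon bound to an aromatic nitrogen. Within the data shown here, no pair of measured compounds shows a comparable change, so there is no measured step to lean on for the size or direction of this one.

Without such a reference, the expectation for compound 3 rests on the value of compound 2 in this assay, 282 nM, with a wide allowance in either direction. Compound 3 is expected to give about 300 nM in this assay, within a range from 90 nM to 1000 nM. The step this estimate means, a 1.1-fold higher number from compound 2 to compound 3 (0.03 log units; within the scatter), is expected to stay close to the scatter rather than beyond it.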

Compound 3, half-maximal effective concentration: 355 nM
For compound 3 the middle estimate is 1.2-fold (0.07 log units) below the measured one, within the range that was stated.
By their numbers in this assay, from the lowest: compounds 2, 3 and 1 (each within the scatter of the next, the first and the last beyond it).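

In this assay, 3,3,3-trifluoropropyl in place of isopropyl on a saturated chain carbon bound to an aromatic nitrogen gives a 1.3-fold higher number from compound 2 to compound 3 (0.10 log units; within the scatter), so the two compounds cannot be told apart on this read-out. Among these compounds, this is the only step in the set that isolates this position, as compound 1 and compound 2 differ in more than one place; it shows that the position accepts a group of 6 heavy atoms, 3 of them fluorine, in place of one of 3 carbon heavy atoms, with no separation beyond the scatter. No evidence at hand explains why this change leaves the two values so close.

The compounds shown leave open whether this tolerance extends to other groups at this position, such as a longer chain, a cyclopropylmethyl group, or a chain ending in an amine or a carboxylic acid. Among the compounds shown here, they also leave open whether the same exchange would give a similar step on a different core, since this single pair is the only reading of it.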